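The source may hold more compounds than are shown below. What is called first, only, known or untested is meant among the compounds shown, and "the series" means these compounds.

Compound 1 `N#Cc1ccc(-c2nc(CO[C@@H]3COc4nc([N+](=O)[O-])cn4C3)cs2)cc1`: in an ADME assay on Vero cells (Chlorocebus sabaeus) for cytotoxicity, with a stated time of 72 h (on this read-out higher numbers stand for weaker inhibition and lower numbers for stronger inhibition), compound 1 gives > 128000 nM, which is a limit of the assay rather than a number.
Compound 2 `COc1ccc(-c2cc(CO[C@@H]3COc4nc([N+](=O)[O-])cn4C3)on2)cn1`: in this assay compound 2 gives > 128000 nM, again a limit.
Compound 3 `O=[N+]([O-])c1cn2c(n1)OC[C@@H](OCc1cnn(-c3ccc(C(F)(F)F)cc3)n1)C2`: in this assay compound 3 gives > 128000 nM, once more a limit.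

Compound 3 therefore stands exactly where the other two stand, at the limit of the read-out: the limit of > 128000 nM in this assay, at which 3 of the 3 values shown sit. Going by the values given here, since every value shown is a limit, no step between measured compounds can be sized, and the numbers say only that none of the three compounds produces a measurable effect on these cells within the range tested.

Compound 4 `O=[N+]([O-])c1cn2c(n1)OC[C@@H](OCc1cnn(-c3ccc(OC(F)(F)F)cc3)n1)C2` has not yet been measured in this assay. It differs from compound 3 in one place: trifluoromethoxy in place of trifluoromethyl on an aromatic carbon. Among the compounds with values here, no measured step offers a guide, so in this assay the expected step is a number no higher from compound 3 to compound 4 (the limit leaves the size open), meaning none beyond the scatter. Compound 4 is expected to give 128000 nM, most likely reported again as a limit, with a range from 64000 nM to 256000 nM.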

Compound 4, half-maximal inhibitory concentration: > 128000 nM
Compound 4 gave a limit, no number (the forecaster's own chance of this, stated with the estimate: 85%); the middle value sits exactly at the limit.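

No step from compound 3 to compound 4 can be read in this assay, because both values are limits rather than numbers: the limit of > 128000 nM in this assay, at which 4 of the 4 values shown sit.

The compounds shown leave open how far each one's true value lies from that limit, and whether trifluoromethoxy in place of trifluoromethyl makes any difference to these cells.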